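One more methyl on the chain of compound 1

The compounds below may be only part of what the source reports. "The series", "measured", "known", "first", "only" and "open" are said of these compounds alone.

Values in a physicochemical assay for lipophilicity, measured as octanol-water partition, with a stated time of 72 h (a higher number here means a more lipophilic compound, a lower number a more polar compound), so far:
compound 1 `CC(C)NC(=O)NO` gives 0.2
compound 2 `CCNC(=O)NO` gives -0.76
compound 3 `CCN(O)C(N)=O` gives -0.1

Compound 1 lies within the scatter of compound 3 and beyond the scatter from compound 2. Compound 4 `CC(C)(C)NC(=O)NO` differs from compound 1 by methyl in place of hydrogen on a saturated chain carbon bound to an amide-type nitrogen and two saturated chain carbons. Within the data shown here, one measured step bears on this change, a modest one: a number 0.96 log units lower from compound 1 to compound 2 (beyond the scatter) (hydrogen in place of methyl on a saturated chain carbon). The change to compound 4 runs the other way, so a higher number in this assay is expected. Among the measured compounds shown here, with only this one step to go on, the expected size is set somewhat smaller than that step. The expected step is a number 0.55 log units higher from compound 1 to compound 4 (beyond the scatter) (an estimate). For compound 4 the estimated value is 0.75 (expected range 0.4 to 1.15).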

Compound 4, partition coefficient: 0.5
For compound 4 the middle estimate is 0.25 log units above the measured one; the range from low to high includes it.
By their numbers in this assay, from the lowest: compound 2; then compounds 3, 1 and 4 (each within the scatter of the next, the first and the last beyond it).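

In this assay the methyl in place of hydrogen on this saturated chain carbon gives a number 0.30 log units higher from compound 1 to compound 4 (within the scatter) and so stays inside the scatter. Among these compounds, the earlier step on this chain, a number 0.96 log units lower from compound 1 to compound 2 (beyond the scatter), lay beyond it, so the one methyl change that is larger at the chain end of compound 1 does not repeat as a clear step here. Nothing at hand explains this difference. The compounds shown leave open whether a longer chain or a phenyl group on this carbon would move this assay beyond the scatter from compound 1 .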